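The compounds below may be only part of what the source reports. "The series", "measured", "known", "first", "only" and "open" are said of these compounds alone.

Measured compounds in a functional assay on HCT-116 cells (Homo sapiens) for antiproliferative activity, read by sulforhodamine B assay, with a stated time of 72 h; on this read-out lower numbers stand for stronger inhibition and higher numbers for weaker inhibition:

Compound 1, `Cn1ncc(Cl)c1-c1cc(C(=O)N[C@@H]2CN[C@H](CC(O)CO)C[C@H]2c2ccc(Cl)c(Cl)c2)oc1Cl`, gives 1110 nM.
Compound 2, `Cn1ncc(Cl)c1-c1cc(C(=O)N[C@@H]2CN[C@H](CCN3CCCCC3)C[C@H]2c2ccc(Cl)c(Cl)c2)oc1Cl`, gives 1020 nM.

Compound 1 holds the highest of the two numbers, and its nearest neighbour is compound 2, separated by a 1.1-fold lower number from compound 1 to compound 2 (0.04 log units; within the scatter), so the two cannot be told apart on this read-out. Going by the values given here, that one step is the only measured change in the data, and it exchanges the 1,2-dihydroxyethyl group for a (piperidin-1-yl)methyl group at the same place on the side chain.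

Compound 3, `CCC[C@@H]1C[C@@H](c2ccc(Cl)c(Cl)c2)[C@H](NC(=O)c2cc(-c3c(Cl)cnn3C)c(Cl)o2)CN1`, has not yet been measured. It differs from compound 1 by ethyl in place of 1,2-dihydroxyethyl on a saturated chain carbon bound to a saturated ring carbon. The change sits at the same position that was altered in the step from compound 1 to compound 2, where a very different replacement left the number essentially unchanged. Among the compounds with values here, with only that step to go on, the expectation for compound 3 is a step of a 1.1-fold lower number from compound 1 to compound 3 (0.05 log units; within the scatter), that is, no shift beyond the scatter in either direction. The estimated value for compound 3 in this assay is therefore 1000 nM, with a range from 400 nM to 2500 nM.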

Compound 3, half-maximal inhibitory concentration: 1020 nM
Estimate against measurement, compound 3: 1.0-fold (0.01 log units) below, within the range that was stated.
By their numbers in this assay, from the lowest: compounds 2, 3 and 1 (each within the scatter of the next).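

In this assay, putting ethyl in place of 1,2-dihydroxyethyl gives a 1.1-fold lower number from compound 1 to compound 3 (0.04 log units; within the scatter), and putting methyl in place of piperidin-1-yl on the same side chain gives no change at the digits printed from compound 2 to compound 3 (within the scatter). Until now, this position had been tested only by swapping one sizeable group for another, whereas ethyl has no ring, with 0 hydrogen-bond donors and 0 hydrogen-bond acceptors, and it still stays within the scatter of both larger groups, so across these three compounds neither the hydroxyl groups nor the piperidine ring makes a readable difference on this read-out, and none of the three goes against that. The data shown offer no explanation for this flat result.

Going by these compounds, it remains open whether this tolerance extends to groups of other kinds at the same place, such as a carboxylic acid, a primary amine or a longer chain like hexyl. On these data alone, all three compounds also share one core and were compared in a single cell assay, so whether the same side chains would behave alike on a different core remains unknown.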